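The source may report more compounds than this note shows. Statements on the series, on what has been measured and on what is new or still open speak of the compounds shown alone.

The compounds measured so far:
compound 1, `CN1CCN(CCNCc2cn(-c3ccc([N+](=O)[O-])cc3)nc2-c2ccc(OC(F)(F)F)cc2)CC1` — 4400 nM
compound 2, `CN1CCN(CCNCc2cn(-c3ccc(F)cc3F)nc2-c2ccc(OC(F)(F)F)cc2)CC1` — 18000 nM
compound 3, `Cc1ccccc1-c1nn(-c2ccc(F)cc2F)cc1CNCc1ccncc1` — a limit of the assay, > 20000 nM

In an ADME assay on Huh-7 cells (Homo sapiens) for cytotoxicity (a lower number here means that less compound is tolerated, a higher number that more compound is tolerated), compound 2 gives 18000 nM, the highest of the two numbers recorded; its nearest neighbour is compound 1, and the step of a 4.1-fold higher number from compound 1 to compound 2 (0.61 log units; beyond the scatter) carries the change 2,4-difluorophenyl in place of 4-nitrophenyl on an aromatic nitrogen. For the measured compounds named here, compound 3 sits at a limit of this assay, > 20000 nM, and that limit is the only evidence on the measured step, (the limit of > 20000 nM in this assay, at which 1 of the 3 values shown sits).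

Compound 4, `CN1CCN(CCNCc2cn(-c3ccc(F)cc3F)nc2-c2ccc(S(=O)(=O)N(C)C)cc2)CC1`, is not yet measured. It differs from compound 2 by dimethylsulfamoyl in place of trifluoromethoxy on an aromatic carbon, on an aromatic carbon of a six-membered aromatic ring of carbon only, para to a large group. Going by the values given here, no measured step touches that ring: the single step recorded, a 4.1-fold higher number from compound 1 to compound 2 (0.61 log units; beyond the scatter), concerns the ring on the aromatic nitrogen, while the 4-(trifluoromethoxy)phenyl ring is shared by compound 1 and compound 2. In this assay the step from compound 2 to compound 4 is therefore expected to stay within the scatter, no change at the digits printed from compound 2 to compound 4 (within the scatter), with no direction favoured. Compound 4 is estimated at 18000 nM, in the range 7000 nM to 45000 nM.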

Compound 4, half-maximal cytotoxic concentration: > 20000 nM
Compound 4: a limit, no number; the forecaster's own chance of this, stated with the estimate: 40%; middle value at least 1.1-fold (0.04 log units) from the limit.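

Compound 1 and compound 2 share the 4-(trifluoromethoxy)phenyl ring, so compound 4 is the only one here that speaks to this position; in this assay compound 4 gives > 20000 nM, which is a limit of the assay and not a number. As far as these compounds go, the change to dimethylsulfamoyl on this aromatic carbon reads as an at least 1.1-fold higher number from compound 2 to compound 4 (0.04 log units; that floor lies within the scatter), so it brings no lower number, but its true size stays unknown and may or may not lie beyond the scatter. The result is therefore bounded from one side only, and such values now make up a larger share of the set: the limit of > 20000 nM in this assay, at which 2 of the 4 values shown sit.

From the compounds shown here alone, what stays open is whether the same change would shift the number with 4-nitrophenyl on the aromatic nitrogen, where compound 1 gives 4400 nM in this assay and a step could be read in full. Also open, going by these compounds, is how other groups on this carbon, such as a methoxy group, a primary sulfonamide or a carboxylic acid, would compare with trifluoromethoxy and dimethylsulfamoyl.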